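Aryl hydrazone variation on a shared core

This account rests on a few compounds, and the source may have more. Where it says the series, first, only, none or still open, it means among the compounds named here.

Three compounds that share one core and differ only in the aryl group on the hydrazone carbon have been measured. Compound 1 `Cn1c(=O)c(=O)n(C2CCCC2)c2nc(N/N=C/c3ccc(S(C)(=O)=O)cc3)ncc21` gives 26600 nM in a functional assay on PC-3 cells (Homo sapiens) for antiproliferative activity, read by MTT assay; on this read-out lower numbers stand for stronger inhibition and higher numbers for weaker inhibition. Compound 2 `COc1cccc(/C=N/Nc2ncc3c(n2)n(C2CCCC2)c(=O)c(=O)n3C)c1` gives 20700 nM in this assay. Compound 3 `Cn1c(=O)c(=O)n(C2CCCC2)c2nc(N/N=C/c3cccc(Cl)c3Cl)ncc21` gives 17200 nM in this assay. The three numbers lie close together: a 1.3-fold lower number from compound 1 to compound 2 (0.11 log units; within the scatter), a 1.5-fold lower number from compound 1 to compound 3 (0.19 log units; within the scatter) and a 1.2-fold lower number from compound 2 to compound 3 (0.08 log units; within the scatter). Compound 3 therefore stands at one end of the set, but its separation from compound 2 and from compound 1 stays within the scatter, so no ordering among the three is supported.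

The next compound, compound 4 `Cn1c(=O)c(=O)n(C2CCCC2)c2nc(N/N=C/c3ccco3)ncc21`, continues the same variation: furan-2-yl in place of 2,3-dichlorophenyl on a carbon with a double bond to nitrogen. All three measured steps bear on this change, since each also swaps the aryl group on the carbon with a double bond to nitrogen, and none of them moved the read-out beyond the scatter. The step to compound 4 is therefore expected to be of the same kind, a 1.2-fold higher number from compound 3 to compound 4 (0.07 log units; within the scatter), with no shift beyond the scatter in either direction. For compound 4 the estimate in this assay is 20000 nM, within a range from 8000 nM to 50000 nM.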

Compound 4, half-maximal inhibitory concentration: 72200 nM
Beside the measured number, compound 4's estimate is 3.6-fold (0.56 log units) below it, outside the stated range (above it).
By their numbers in this assay, from the lowest: compounds 3, 2 and 1 (each within the scatter of the next); then compound 4.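

In this assay, the aryl group on the carbon with a double bond to nitrogen turns out to matter: furan-2-yl gives a 4.2-fold higher number from compound 3 to compound 4 (0.62 log units; beyond the scatter), a 3.5-fold higher number from compound 2 to compound 4 (0.54 log units; beyond the scatter) and a 2.7-fold higher number from compound 1 to compound 4 (0.43 log units; beyond the scatter), all three modest, whereas the earlier swaps among the substituted phenyl groups all stayed within the scatter. The position therefore accepts 2,3-dichlorophenyl, 3-methoxyphenyl and 4-(methylsulfonyl)phenyl without a separable difference, but compound 4, with a five-membered aromatic ring carrying one hetero atom, stands apart from all of them on the weaker side. Nothing measured alongside these numbers accounts for this separation.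

The change from 2,3-dichlorophenyl to furan-2-yl alters ring size, heavy-atom count and hydrogen-bond acceptor count together, so the compounds shown do not tell which of these goes with the higher number. A thiophen-2-yl group or an unsubstituted phenyl group on the same carbon would help to separate these factors, and a basic amine on the phenyl ring would test whether any group at this position moves the number below the cluster of compounds 1, 2 and 3.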